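The source may report more compounds than this note shows. Statements on the series, on what has been measured and on what is new or still open speak of the compounds shown alone.

Compound 1 `O=S(=O)(/C=C/c1ccc(O)c(O)c1)NCc1ccccc1`: 21500 nM
Compound 2 `O=S(=O)(/C=C/c1ccc(O)c(O)c1)NCCCCc1ccccc1`: 23800 nM
Compound 3 `O=S(=O)(/C=C/c1ccc(O)c(O)c1)NCc1ccc(Cl)cc1`: 13700 nM

In a functional assay on BV-2 cells (Mus musculus) for inhibition, read by Griess assay, with stated times of 3 h and 24 h (on this read-out lower numbers stand for stronger inhibition and higher numbers for weaker inhibition), compound 3 gives the lowest of the three numbers, but its gaps to compound 1 and to compound 2 are both within the scatter, so none of the three can be called more or less potent than the others. Compound 4 `O=S(=O)(/C=C/c1ccc(O)c(O)c1)NCc1ccc(C(F)(F)F)cc1` differs from compound 3 in one place: trifluoromethyl in place of chloro on an aromatic carbon. Within the data shown here, only one measured step touches this position on the ring: a 1.6-fold lower number from compound 1 to compound 3 (0.20 log units; within the scatter). Among the measured compounds shown here, no measured compound carries a trifluoromethyl group, so nothing here shows directly what that group does. For the measured compounds named here, since the one step at this spot was small, compound 4 is expected to show a step of a 1.1-fold lower number from compound 3 to compound 4 (0.06 log units; within the scatter), not clearly beyond the scatter. Compound 4 is therefore estimated at 12000 nM, with a range from 5000 nM to 30000 nM.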

Compound 4, half-maximal inhibitory concentration: 12600 nM
Estimate against measurement, compound 4: 1.1-fold (0.02 log units) below, and the stated range covers the measured number.
By their numbers in this assay, from the lowest: compounds 4, 3, 1 and 2 (each within the scatter of the next).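

In this assay, replacing chloro with trifluoromethyl puts four heavy atoms where there was one, yet the change gives only a 1.1-fold lower number from compound 3 to compound 4 (0.04 log units; within the scatter), so this position tolerates the swap with no difference that can be told from scatter. Compared with hydrogen at the same position, trifluoromethyl gives a 1.7-fold lower number from compound 1 to compound 4 (0.23 log units; within the scatter), so this group, like chloro before it, does not separate clearly from the unsubstituted compound. Nothing available bears on why these groups read so alike.

From the compounds shown here alone, it remains open whether a different kind of group at this position, such as an amine or a carboxylic acid, would move the number beyond the scatter. Going by these compounds, it is also open whether chloro or trifluoromethyl would read the same on the ring of compound 2, with its longer chain.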